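The source may hold more compounds than are shown below. What is called first, only, known or untested is meant among the compounds shown, and "the series" means these compounds.

Measured compounds in an ADME assay on PC-3 cells (Homo sapiens) for cytotoxicity, read by WST assay, tested at 100 uM; a lower number here means less inhibition, a higher number more inhibition at the concentration tested (going by the name of the read-out):
- compound 1, `Cc1nc(-c2cccc(C(=O)N3CCCC(C(=O)Nc4ccc(Cl)cc4)C3)c2)no1`, gives 0%
- compound 2, `O=C(Nc1cccc(Cc2ccccc2)c1)C1CCCN(C(=O)c2cccc(-c3ccco3)c2)C1`, gives 0%
- compound 3, `O=C(Nc1cccc(S(=O)(=O)N2CCCC2)c1)C1CCCN(C(=O)c2cc(C(F)(F)F)cc(C(F)(F)F)c2)C1`, gives 0%

All three compounds share a central ring carrying an amide on each side, and each of them shows no measurable inhibition of cell growth at the single concentration tested. Compound 1 therefore stands level with compounds 2 and 3 at the digits recorded; its nearest neighbour in value is compound 2, its furthest is compound 3, and in both cases the difference lies within the scatter of repeated measurements, so no order among them can be read.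

Compound 4, `N#Cc1cccc(C(=O)N2CCCC(C(=O)Nc3ccc(Cl)cc3)C2)c1`, has not yet been measured. It differs from compound 1 in one place: cyano in place of 5-methyl-1,2,4-oxadiazol-3-yl on an aromatic carbon. The rest of the molecule, including the chlorinated aniline amide, is unchanged.

Among the measured compounds shown here, no pair of measured compounds differing in a single place is available, so the size of this kind of step cannot be drawn from the data. Since compounds 1, 2 and 3 all sit at the floor of this assay despite carrying quite different side groups, the expected step is none beyond the scatter, no change at the digits printed from compound 1 to compound 4 (within the scatter). Compound 4 is estimated to give 0%, within a range from 0% to 10%.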

Compound 4, a percentage reported as inhibition, at one concentration (the size of the read-out at that concentration, not a potency): 0%
Estimate against measurement, compound 4: no gap at the digits printed; measured number inside the range.
By their numbers in this assay, from the lowest: compounds 1, 2, 3 and 4 (each within the scatter of the next).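

In this assay, among the compounds shown here, this is the first step between two compounds that differ in one place: no change at the digits printed from compound 1 to compound 4 (within the scatter), with cyano in place of 5-methyl-1,2,4-oxadiazol-3-yl on an aromatic carbon of a six-membered aromatic ring of carbon only. The earlier compounds shown here differed from one another in several places, so they could say nothing about this position alone, whereas here a group of 6 heavy atoms with a five-membered aromatic ring gives way to one of 2 heavy atoms with no ring, and the reading stays the same. No measurement shown gives a reason for this result.

Going by these compounds, all four compounds give the same reading, so it remains unknown whether a change at this position would show an effect in a compound that starts from a higher value. On these data alone, it also remains open whether an amine or a carboxylic acid on this aromatic carbon would give a reading different from that of compound 4.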